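Swapping the amide for an acetamidocyclohexyl group

The source may hold more compounds than are shown below. What is called first, only, known or untested is meant among the compounds shown, and "the series" means these compounds.

Measured so far:
compound 1, `Clc1cnc(Nc2ccccc2)cc1-c1csc(NCC2CCOCC2)n1`, in a functional assay on MV4-11 cells (Homo sapiens) for antiproliferative activity, read by CellTiter-Glo, with a stated time of 72 h (a higher number here means a weaker inhibitor of growth, a lower number a stronger inhibitor of growth), gives the limit > 10000 nM.
compound 2, `O=C(Nc1cc(-c2csc(NCC3CCOCC3)n2)c(Cl)cn1)c1ccc(F)cc1`, in this assay gives 550 nM.

Among the measured compounds shown here, compound 2 holds the only actual number here; the value for compound 1 is a limit of the assay, as the limit of > 10000 nM in this assay, at which 1 of the 2 values shown sits, records. Compound 3, `CC(=O)N[C@H]1CC[C@H](Nc2cc(-c3csc(NCC4CCOCC4)n3)c(Cl)cn2)CC1`, differs from compound 2 by 4-acetamidocyclohexyl in place of (4-fluorophenyl)carbonyl on a nitrogen on an aromatic ring. For the measured compounds named here, the single measured step, an at least 18-fold lower number from compound 1 to compound 2 (1.25 log units; beyond the scatter), concerns the same nitrogen but a different group, so it shows only that this position matters greatly. Compound 3 is therefore expected to stay near compound 2, with a 1.6-fold lower number from compound 2 to compound 3 (0.20 log units; within the scatter) as a modest change. The estimate for compound 3 is 350 nM, within 60 nM to 3000 nM.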

Compound 3, concentration for 50% growth inhibition: 3600 nM
For compound 3 the middle estimate is 10-fold (1.01 log units) below the measured one; measured number outside the range, above it.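

At the nitrogen on the aromatic ring, 4-acetamidocyclohexyl does worse than (4-fluorophenyl)carbonyl, with a 6.5-fold higher number from compound 2 to compound 3 (0.82 log units; beyond the scatter). It still does better than phenyl, with an at least 2.7-fold lower number from compound 1 to compound 3 (0.44 log units; beyond the scatter). Compound 1 has no true number here, only a limit of the assay: the limit of > 10000 nM in this assay, at which 1 of the 3 values shown sits.

The compounds shown do not separate the effect of the carbonyl on this nitrogen from that of the ring it carries. A cyclohexylcarbonyl group would keep the carbonyl and the non-aromatic ring together, and a 4-aminocyclohexyl group would show what the acetyl part contributes.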